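A few compounds are considered here, and "the series" means these few. Any claim that something is new, unique, unknown or untested is made for them only; others in the source may bear on it.

Compound 1 `CCOc1nc(N)nc2ncc(-c3ccc(Cl)c(Cl)c3)nc12`: > 10000 nM
Compound 2 `CC(C)Oc1nc(N)nc2ncc(-c3ccc(C#N)cc3)nc12`: > 10000 nM
Compound 3 `COc1ccc(-c2cnc3nc(N)nc(N4CCN(c5cc(Cl)cc(Cl)c5)CC4)c3n2)cc1OC`: 3400 nM

Of the compounds shown here, three have so far been tested in a functional assay on cells (T-cell, Homo sapiens) for inhibition; a lower number here means a stronger inhibitor, a higher number a weaker inhibitor. For compound 1 the result is only the limit of this assay, > 10000 nM, so no number is known for it. Compound 2 likewise gives only the limit, > 10000 nM. Two of the three results therefore sit at the limit of > 10000 nM in this assay, at which 2 of the 3 values shown sit. Going by the values given here, compound 3 is the one compound for which this assay returned a number, 3400 nM, and it is the only number to work with here.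

Compound 4 `COc1ccc(-c2cnc3nc(N)nc(N4CCN(C(=O)CCc5ccccc5)CC4)c3n2)cc1OC` has not yet been measured. It differs from compound 3 in one place: phenethylcarbonyl in place of 3,5-dichlorophenyl on an amine nitrogen in a ring. Among the compounds with values here, no pair of measured compounds differs in a single place, so no measured step shows what such a change does to the result in this assay. The expectation therefore rests on compound 3 alone. The step is expected to be small, if anything toward a weaker inhibitor, and it may well stay within the usual scatter: a 1.5-fold higher number from compound 3 to compound 4 (0.17 log units; within the scatter). Compound 4 is thus estimated to give 5000 nM in this assay, with a plausible range from 1000 nM to 20000 nM.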

Compound 4, half-maximal inhibitory concentration: 100 nM
For compound 4 the middle estimate is 50-fold (1.70 log units) above the measured one; the whole stated range lies above it.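

In this assay, going by these compounds alone, putting phenethylcarbonyl in place of 3,5-dichlorophenyl on the amine nitrogen of the six-membered ring gives a 34-fold lower number from compound 3 to compound 4 (1.53 log units; beyond the scatter), the first single-place change that can be read. It shows that this position is far from silent: what sits on that nitrogen can strongly change the result, and a carbonyl-linked group with a phenyl ring at the end of its chain goes with a much stronger inhibitor here than a phenyl ring attached directly. It also adds a second real number to a set in which most results could not be compared: the limit of > 10000 nM in this assay, at which 2 of the 4 values shown sit.

This single pair cannot separate the parts of the change, since the carbonyl, the chain and the loss of the chlorines all arrive together, and it gives no reason for the size of the step. A shorter or longer chain on the carbonyl, a sulfonyl in place of the carbonyl, or chlorine atoms on the phenyl ring of the phenethylcarbonyl group would each test one of those parts on its own.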